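The source may report more compounds than this note shows. Statements on the series, on what has been measured and on what is new or still open speak of the compounds shown alone.

In a physicochemical assay for solubility, measured as kinetic solubility, at pH 7.4 (on this read-out lower numbers stand for lower solubility and higher numbers for higher solubility), compound 2 `COc1cc(N2CCN(Cc3ccccn3)CC2)ccc1Nc1nc(NC2CCCCC2)c2nc[nH]c2n1` gives 38000 nM and compound 1 `COc1cc(N2CCN(C(=O)C3CCC(O)CC3)CC2)ccc1Nc1nc(NC2CCCCC2)c2nc[nH]c2n1` gives 19000 nM, so these two numbers lie within the scatter of each other and neither stands clear of the other. Compound 3 `COc1cc(N2CCN(C(=O)N3CCC(O)C3)CC2)ccc1Nc1nc(NC2CCCCC2)c2nc[nH]c2n1` has not yet been measured. Its difference from compound 2 is (3-hydroxypyrrolidin-1-yl)carbonyl in place of (pyridin-2-yl)methyl on an amine nitrogen in a ring. In words, (3-hydroxypyrrolidin-1-yl)carbonyl stands in place of (pyridin-2-yl)methyl on an amine nitrogen in a ring. Going by the values given here, only one measured step bears on this change: a 2.0-fold higher number from compound 1 to compound 2 (0.30 log units; within the scatter), where (pyridin-2-yl)methyl replaced (4-hydroxycyclohexyl)carbonyl at the same place, and that step stayed within the scatter. Among the compounds with values here, the entering group resembles the one on compound 1, which also has a hydroxy-bearing ring attached through a carbonyl and gives 19000 nM. No step beyond the scatter is therefore expected in this assay, although two compounds are a thin basis for any forecast. The estimated change is a 1.5-fold lower number from compound 2 to compound 3 (0.18 log units; within the scatter), which would remain within the scatter. For compound 3 the expected value is 25000 nM, with an estimated range from 10000 nM to 60000 nM.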

Compound 3, solubility: 19000 nM
Compound 3: middle estimate off by 1.3-fold (0.12 log units), on the high side; measured number inside the range.
By their numbers in this assay, from the lowest: compounds 1, 3 and 2 (each within the scatter of the next).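

In this assay, the step of a 2.0-fold lower number from compound 2 to compound 3 (0.30 log units; within the scatter) puts a second carbonyl-linked group against (pyridin-2-yl)methyl on the amine nitrogen in a ring, and it stays within the scatter just as the earlier step did. Going by these compounds alone, the step of no change at the digits printed from compound 1 to compound 3 (within the scatter) is the first to compare two hydroxy-bearing rings on a carbonyl carbon, and exchanging 4-hydroxycyclohexyl for 3-hydroxypyrrolidin-1-yl leaves the printed number unchanged. All three groups at this place therefore lie within the scatter of one another, and nothing shown here accounts for that reading.

The compounds shown leave open whether any group on this nitrogen can move the number beyond the scatter, for instance a carboxylic acid at the end of a longer chain or a dimethylamino group on the carbonyl. They also leave open what the hydroxy group contributes in this assay, since compound 1 and compound 3 both carry one and a matching ring without it would be needed to tell.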